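The source may hold more compounds than are shown below. What is called first, only, known or untested is meant among the compounds shown, and "the series" means these compounds.

Of the compounds shown here, three sharing one core have been measured in an assay on CHO cells for displacement of a labelled ligand from Alpha-2B adrenergic receptor (Homo sapiens); on this read-out higher numbers stand for weaker inhibition and lower numbers for stronger inhibition. Compound 1 `Cc1cccc(C)c1OC(C)C1=NCCN1` gives 182 nM. Compound 2 `CCc1ccccc1OC(C)C1=NCCN1` gives 282 nM, and compound 3 `C=CCc1cccc(CC=C)c1OC(C)C1=NCCN1` gives 275 nM. Among these three numbers compound 2 carries the highest one, but the gaps to compound 3 and to compound 1 both lie within the usual scatter of this assay, so the three compounds cannot be told apart on these data.

The next compound to be measured is compound 4 `CCOc1ccccc1OC(C)C1=NCCN1`. It differs from compound 2 in a single place: ethoxy in place of ethyl on an aromatic carbon. The change sits on an aromatic carbon of a six-membered aromatic ring of carbon only, ortho to a group of 8 heavy atoms, where an ethyl gives way to an ethoxy, which brings one hydrogen-bond acceptor where there was none.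

For the measured compounds named here, no measured pair in this set shows what such a swap does, so the expectation rests only on the spread of the three known values. The step from compound 2 is expected to be small, with the estimated change a 1.2-fold higher number from compound 2 to compound 4 (0.09 log units; within the scatter) most likely staying within the scatter or drifting slightly toward a weaker number. For compound 4 the estimate in this assay is 350 nM, with a range from 120 nM to 1000 nM.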

Compound 4, inhibition constant: 1320 nM
Compound 4: the middle estimate sits 3.8-fold (0.58 log units) below what was measured, outside the stated range (above it).
By their numbers in this assay, from the lowest: compounds 1, 3 and 2 (each within the scatter of the next); then compound 4.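

In this assay, for the compounds shown here, the swap of ethyl for ethoxy gives a 4.7-fold higher number from compound 2 to compound 4 (0.67 log units; beyond the scatter) and so provides the first measured step in this set, one that lies beyond the scatter. It shows that this place on the aromatic ring, ortho to a group of 8 heavy atoms, is sensitive to what is attached there: even a change of one oxygen atom, which also brings one hydrogen-bond acceptor, goes with clearly weaker inhibition in this pair. Nothing in the available data explains why the number rises, so this single pair records an effect but not its cause.

The pair cannot separate the contribution of the oxygen from that of the longer group, and a propyl or methoxy group at the same place would be needed to pull the two apart. Also open, going by these compounds, is whether the swap would have a similar effect in compounds with a second group on the ring, such as compound 1 and compound 3, or whether a hydroxyl or an amine here would behave like the ethoxy.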